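Propanoyl for 4-nitrophenyl on a second pyrazoline core

A few compounds are considered here, and "the series" means these few. Any claim that something is new, unique, unknown or untested is made for them only; others in the source may bear on it.

The measured compounds:
compound 1, `CCC(=O)N1N=C(c2ccc(F)cc2)CC1c1cn(-c2ccccc2)nc1-c1ccc(Cl)c(Cl)c1`, 63.4%
compound 2, `O=[N+]([O-])c1ccc(N2N=C(c3ccc(F)cc3)CC2c2cn(-c3ccccc3)nc2-c2ccc(Cl)c(Cl)c2)cc1`, 60.3%
compound 3, `O=[N+]([O-])c1ccc(N2N=C(c3ccc(Cl)cc3)CC2c2cn(-c3ccccc3)nc2-c2ccc(Cl)c(Cl)c2)cc1`, 57.3%

In a functional assay on the whole organism (strain Wistar) for inhibition, with Rattus norvegicus as the target, read by paw edema, with stated times of 30 min and 60 min, at a dose of 50 mg/kg by the oral route (on this read-out lower numbers stand for less inhibition and higher numbers for more inhibition at the one dose given (going by the name of the read-out)), compound 1 gives 63.4%, compound 2 gives 60.3% and compound 3 gives 57.3%. Compound 3 stands lowest of the three numbers, but its steps to compound 2, a number 3 percentage points lower from compound 2 to compound 3 (within the scatter), and to compound 1 are within the scatter, so no order can be read among them. The change from compound 2 to compound 1 is propanoyl in place of 4-nitrophenyl on an amine nitrogen in a ring, and it gave a number 3.1 percentage points higher from compound 2 to compound 1 (within the scatter).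

Compound 4, `CCC(=O)N1N=C(c2ccc(Cl)cc2)CC1c1cn(-c2ccccc2)nc1-c1ccc(Cl)c(Cl)c1`, has not yet been measured in this assay. It arises from compound 3 by propanoyl in place of 4-nitrophenyl on an amine nitrogen in a ring. This is the same kind of change as that from compound 2 to compound 1; the two cores differ by chloro in place of fluoro on an aromatic carbon, so the place line of compound 4 names a 4-chlorophenyl group where that of compound 1 names a 4-fluorophenyl group. Because the earlier step of a number 3.1 percentage points higher from compound 2 to compound 1 (within the scatter) stayed within the scatter, the step for compound 4 is expected to be a number 3.1 percentage points higher from compound 3 to compound 4 (within the scatter). Compound 4 is therefore estimated at 60.4%, between 50% and 70%.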

Compound 4, a percentage reported as inhibition, in the whole organism at one dose (the size of the read-out at that dose, not a potency): 61.1%
Compound 4: middle estimate off by 0.7 percentage points, on the low side, within the range that was stated.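

In this assay, propanoyl in place of 4-nitrophenyl on the amine nitrogen in the ring gave a number 3.8 percentage points higher from compound 3 to compound 4 (within the scatter), and this agrees with the same change on the other core: the same change on two cores in this assay, a number 3.1 percentage points higher (within the scatter) from compound 2 to compound 1 and a number 3.8 percentage points higher (within the scatter) from compound 3 to compound 4, 0.7 percentage points apart, within the scatter of two such steps. Chloro in place of fluoro on an aromatic carbon, read here on the propanoyl compounds, gave a number 2.3 percentage points lower from compound 1 to compound 4 (within the scatter), and this also agrees with its earlier counterpart: the same change on two cores in this assay, a number 3 percentage points lower (within the scatter) from compound 2 to compound 3 and a number 2.3 percentage points lower (within the scatter) from compound 1 to compound 4, 0.7 percentage points apart, within the scatter of two such steps. Each change thus carried over between these two cores with a step of like size, but every step lies within the scatter, so this does not show that either change truly alters the read-out, and it says nothing beyond these four compounds.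

The compounds shown leave open whether another group on that ring nitrogen, such as acetyl, a longer acyl chain or an unsubstituted phenyl, would give a step beyond the scatter. They also leave open how bromo or methoxy would read in place of the chloro or fluoro on the aromatic carbon.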